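Methoxy for methyl on the sulfonyl-bearing ring

The compounds below may be only part of what the source reports. "The series", "measured", "known", "first", "only" and "open" are said of these compounds alone.

Measured so far:
compound 1 `COc1ccc(S(=O)(=O)c2c(C)cc(C)cc2C)cc1` gives 1900 nM
compound 2 `CCc1cccn1S(=O)(=O)c1ccc(C)cc1` gives 4000 nM

Of the compounds shown here, two have been tested in an assay on isolated protein for antagonist activity at Rap guanine nucleotide exchange factor 4 (Homo sapiens), read by fluorescence and cAMP accumulation; on this read-out lower numbers stand for stronger inhibition and higher numbers for weaker inhibition. Compound 1 `COc1ccc(S(=O)(=O)c2c(C)cc(C)cc2C)cc1` gives 1900 nM in this assay, and compound 2 `CCc1cccn1S(=O)(=O)c1ccc(C)cc1` gives 4000 nM, the higher of the two numbers; the gap between them lies beyond the scatter, but the two compounds differ in more than one place, so no single change can be credited for it.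

Compound 3 `CCc1cccn1S(=O)(=O)c1ccc(OC)cc1` is not yet measured. Relative to compound 2, the change is methoxy in place of methyl on an aromatic carbon. For the measured compounds named here, no pair of measured compounds differs by this change alone, so the size of its step is unknown. The estimate for compound 3 is 3000 nM in this assay, with a range from 1200 nM to 7500 nM. The expected step of a 1.3-fold lower number from compound 2 to compound 3 (0.12 log units; within the scatter) is small and within the scatter.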

Compound 3, half-maximal inhibitory concentration: 8000 nM
Compound 3: the middle estimate sits 2.7-fold (0.43 log units) below what was measured; measured number above the stated range.
By their numbers in this assay, from the lowest: compound 1; then compounds 2 and 3 (each within the scatter of the next).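

In this assay, methoxy in place of methyl on an aromatic carbon, para to a large group, now has a measured size, a 2.0-fold higher number from compound 2 to compound 3 (0.30 log units; within the scatter) and so this change does not separate compound 2 from compound 3 on this read-out. The earlier compounds shown here could not show this, since compound 1 and compound 2 differ in more than one place. Nothing at hand bears on what lies behind this step.

On these data alone, whether an amine, a carboxylic acid or a longer chain at this place would give a step beyond the scatter remains open. As far as these compounds go, it is also open whether the same exchange of methyl and methoxy would give a step of similar size on the core of compound 1, where the rest of the molecule differs.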